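The source may hold more compounds than are shown below. What is called first, only, known or untested is meant among the compounds shown, and "the series" means these compounds.

Going by the values given here, compound 2 `CCc1sc(CCc2cc(OC3CCC3)cc(NCc3cc(Cl)cc(NC(=O)OC(C)C)c3)n2)nc1C` gives 11 nM in an assay on cells for binding affinity to Neuropeptide Y receptor type 1 (Homo sapiens) (on this read-out higher numbers stand for weaker inhibition and lower numbers for stronger inhibition), the lowest of the two numbers measured so far; compound 1 `CCc1sc(CCc2cc(OCC(C)(C)C)cc(NCc3cc(Cl)cc(NC(=O)OC(C)C)c3)n2)nc1C` gives 55 nM in this assay. Among the compounds with values here, the change from compound 1 to compound 2 was a 5.0-fold lower number from compound 1 to compound 2 (0.70 log units; beyond the scatter), the only step that touches the same oxygen. Compound 3 `CCc1sc(CCc2cc(OCCc3ccccc3)cc(NCc3cc(Cl)cc(NC(=O)OC(C)C)c3)n2)nc1C` differs from compound 2 by phenethyl in place of cyclobutyl on an oxygen on an aromatic ring. That earlier step shows the number can move modestly at this position, and phenethyl is, like the neopentyl of compound 1, no small ring, so a moderate rise is expected, giving a 2.7-fold higher number from compound 2 to compound 3 (0.44 log units; beyond the scatter). Compound 3 is therefore estimated at 30 nM, between 8 nM and 120 nM.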

Compound 3, half-maximal inhibitory concentration: 30 nM
Estimate against measurement, compound 3: no gap at the digits printed; low and high end bracket the measured number.
By their numbers in this assay, from the lowest: compound 2; then compounds 3 and 1 (each within the scatter of the next).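

In this assay, an ether ending in an aromatic ring reads differently from the cyclobutyl ether, with a 2.7-fold higher number from compound 2 to compound 3 (0.44 log units; beyond the scatter). Set against the saturated chain of compound 1, the phenethyl group gives a 1.8-fold lower number from compound 1 to compound 3 (0.26 log units; within the scatter), so these two differently shaped groups cannot be told apart, and only cyclobutyl stands apart from both. Nothing available explains this separation. Going by these compounds, it remains open whether another small ring such as cyclopentyl, or a chain carrying an amine, would read like cyclobutyl or like the other two groups.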